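This account rests on a few compounds, and the source may have more. Where it says the series, first, only, none or still open, it means among the compounds named here.

Of the compounds shown here, three built on one shared core have been measured in a functional assay on SK-OV-3 cells (Homo sapiens) for antiproliferative activity, read by MTT assay, with a stated time of 72 h; on this read-out lower numbers stand for stronger inhibition and higher numbers for weaker inhibition. Compound 1 `O=C(CCc1cccc2c1B(O)OC2)Nc1ccc([N+](=O)[O-])cc1` gives 83000 nM, compound 2 `CC(C)c1cccc(NC(=O)CCc2cccc3c2B(O)OC3)c1` gives 510 nM, and compound 3 `O=C(CCc1cccc2c1B(O)OC2)Nc1cccc2ccccc12` gives 170 nM. Compound 2 thus stands second highest of the three numbers, with compound 3 nearest to it and compound 1 furthest away. Compound 4 `N#Cc1ccc(-c2cccc(NC(=O)CCc3cccc4c3B(O)OC4)c2)cc1` has not yet been measured in this assay; it differs from compound 2 in one place: 4-cyanophenyl in place of isopropyl on an aromatic carbon. Going by the values given here, no step between measured compounds differing in a single place is available to guide the expectation. Compound 3, which carries the larger aromatic group, gives 170 nM, while compound 2 gives 510 nM. A modest move toward a lower number is therefore expected, a 1.7-fold lower number from compound 2 to compound 4 (0.23 log units; within the scatter), perhaps not beyond the scatter. Compound 4 is estimated at 300 nM, within a range from 80 nM to 1200 nM.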

Compound 4, half-maximal inhibitory concentration: 340 nM
Beside the measured number, compound 4's estimate is 1.1-fold (0.05 log units) below it; the range from low to high includes it.
By their numbers in this assay, from the lowest: compounds 3, 4 and 2 (each within the scatter of the next, the first and the last beyond it); then compound 1.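

In this assay, going by these compounds alone, the first step that changes a single place reads a 1.5-fold lower number from compound 2 to compound 4 (0.18 log units; within the scatter) and so separates the two compounds by no more than the usual scatter. On this aromatic carbon, meta to a large group, the six-membered aromatic ring and nitrile of 4-cyanophenyl can thus replace isopropyl with no clear shift in the number. No measurement shown here offers an explanation for this result.

On these data alone, it remains open whether a plain phenyl would read the same, which would show what the nitrile adds. An amine or a carboxylic acid on this carbon is also untested among the compounds shown.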